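The source may report more compounds than this note shows. Statements on the series, on what has been measured and on what is new or still open speak of the compounds shown alone.

Measured compounds:
Compound 1 `CCOc1ccc(-n2c(S)nnc2CSc2nnc(-c3ccccc3)n2-c2ccccc2)cc1` — a functional assay on HT-29 cells (Homo sapiens) for inhibition, read by MTT assay, with a stated time of 48 h; a higher number here means a weaker inhibitor, a lower number a stronger inhibitor: "not determined" (no result reported)
Compound 2 `Sc1nnc(Sc2nnc(-c3ccccc3)n2-c2ccccc2)n1-c1ccccc1` — this assay: 28300 nM
Compound 3 `CCOc1ccc(-n2c(S)nnc2Sc2nnc(-c3ccccc3)n2-c2ccccc2)cc1` — this assay: 46800 nM

Compound 1 stands without a number in this assay; no result was reported for it, so it cannot be placed against the other two. Among the compounds with values here, compound 2 and compound 3 are the only measured pair, and they differ by ethoxy in place of hydrogen on an aromatic carbon, a step that gives a 1.7-fold higher number from compound 2 to compound 3 (0.22 log units; within the scatter) and so reads as no real change.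

Compound 4 `Sc1nnc(CSc2nnc(-c3ccccc3)n2-c2ccccc2)n1-c1ccccc1` is the unmeasured compound. It differs from compound 1 by hydrogen in place of ethoxy on an aromatic carbon. The step from compound 2 to compound 3 is the same change run in the opposite direction, and it bears directly on this one; since it stayed within the scatter, no shift beyond the scatter is expected from removing the ethoxy group. Because compound 1 has no value, the expectation for compound 4 must rest on the values of compound 2 and compound 3, which are its nearest measured relatives. Compound 4 is therefore estimated at 32000 nM in this assay, with a range from 10000 nM to 100000 nM.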

Compound 4, half-maximal inhibitory concentration: 5490 nM
Beside the measured number, compound 4's estimate is 5.8-fold (0.77 log units) above it, and the stated range ends above it.
By their numbers in this assay, from the lowest: compound 4; then compounds 2 and 3 (each within the scatter of the next).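

In this assay, within the data shown here, compound 1 stands at "not determined" (no result reported), so no step from compound 1 to compound 4 can be read for the change from 4-ethoxyphenyl to phenyl. The compounds shown leave open what the ethoxy group does to the number in the core of compound 4. Nothing given here offers an explanation for the result.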